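Swapping Two Halogens on the Aryl Ketone of Compound 2

The source may report more compounds than this note shows. Statements on the series, on what has been measured and on what is new or still open speak of the compounds shown alone.

Measured compounds:
- Compound 1 `COc1ccc(-c2cc(/C=C/C(=O)c3ccc(N)cc3)[nH]n2)cc1` gives 94% in a functional assay on MCF7 cells (Homo sapiens) for cytotoxicity, read by sulforhodamine B assay, with a stated time of 48 h, tested at 0.1 uM; a higher number here means a weaker effect of the compound at the concentration tested, a lower number a stronger effect
- Compound 2 `COc1cc(-c2cc(/C=C/C(=O)c3ccc(Cl)c(Cl)c3)[nH]n2)cc(OC)c1OC` gives 105% in this assay
- Compound 3 `COc1ccc(C(=O)/C=C/c2cc(-c3cc(OC)c(OC)c(OC)c3)n[nH]2)cc1OC` gives 91% in this assay

Compound 2 has the highest number of the three, so at this concentration it shows the weakest effect. Compound 1 lies below it, and compound 3 lies further below it; both gaps are beyond the scatter.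

The unmeasured compound 4 `COc1cc(-c2cc(/C=C/C(=O)c3ccc(F)c(F)c3)[nH]n2)cc(OC)c1OC` differs from compound 2 in one place: 3,4-difluorophenyl in place of 3,4-dichlorophenyl on a carbonyl carbon. Among the compounds with values here, the only measured step at this same place is a number 14 percentage points lower from compound 2 to compound 3 (beyond the scatter), where a 3,4-dimethoxyphenyl rather than a 3,4-difluorophenyl replaced the 3,4-dichlorophenyl. That step shows the position can move the number modestly, but it does not show what exchanging one pair of halogens for another does. Within the data shown here, no measured compound carries a 3,4-difluorophenyl, so the direction is open.

With only that indirect hint, the expectation for compound 4 is a number close to that of compound 2, with a step of a number 5 percentage points lower from compound 2 to compound 4 (within the scatter) that is expected to sit within the scatter, perhaps leaning slightly lower. The estimate for compound 4 is 100%, expected to fall between 86% and 112%.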

Compound 4, a percentage reported as activity, at one concentration (the size of the read-out at that concentration, not a potency): 98%
Compound 4: the middle estimate sits 2 percentage points above what was measured; measured number inside the range.
By their numbers in this assay, from the lowest: compounds 3, 1, 4 and 2 (each within the scatter of the next, the first and the last beyond it).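

The exchange of 3,4-dichlorophenyl for 3,4-difluorophenyl on the carbonyl carbon gives a number 7 percentage points lower from compound 2 to compound 4 (within the scatter) in this assay, so at this single concentration the two halogen pairs cannot be told apart. The 3,4-difluorophenyl compound also cannot be told apart from the 3,4-dimethoxyphenyl compound, with a number 7 percentage points higher from compound 3 to compound 4 (within the scatter), even though the earlier step of a number 14 percentage points lower from compound 2 to compound 3 (beyond the scatter) separates the dichloro and dimethoxy compounds; compound 4 therefore fits with either of them and does not show a clear boundary at this position. Nothing available explains why these numbers fall as they do.

The compounds shown leave open whether a different group on this ring, such as a carboxylic acid, a nitrile or a trifluoromethyl group, would produce a step beyond the scatter from compound 4. They also leave open whether the halogen exchange would separate compound 2 and compound 4 at other concentrations, since a read-out at one concentration is not a potency.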